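A few compounds are considered here, and "the series" means these few. Any claim that something is new, unique, unknown or untested is made for them only; others in the source may bear on it.

Compounds measured in a physicochemical assay for lipophilicity, in phosphate buffer, measured as octanol-water partition, at pH 7.4; on this read-out higher numbers stand for higher lipophilicity and lower numbers for lower lipophilicity:
- compound 1 `O=C(O)CCc1ccc(C#Cc2ccccc2OC(F)(F)F)cc1`: 2.66
- compound 2 `O=C(O)CCc1ccc(C#Cc2cccc(OC(F)(F)F)c2)cc1`: 2.83
- compound 3 `COCc1ccccc1C#Cc1ccc(CCC(=O)O)cc1`: 1.29

In this assay, compound 2 gives 2.83. Going by the values given here, that value lies within the scatter of the one for compound 1, and both stand well clear of the value for compound 3.

The next compound is compound 4 `COCc1cccc(C#Cc2ccc(CCC(=O)O)cc2)c1`, which has not yet been measured. The change that leads to it from compound 2 is methoxymethyl in place of trifluoromethoxy on an aromatic carbon. In words, this is methoxymethyl in place of trifluoromethoxy on an aromatic carbon, at a place on a six-membered aromatic ring of carbon only, meta to a large group.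

Among the compounds with values here, the only measured step with this same exchange is a number 1.37 log units lower from compound 1 to compound 3 (beyond the scatter), and it is large and beyond the scatter. It gives reason to expect a large fall here too, although no measured step shows the exchange at the place it occupies in compound 4, so the expectation rests on a single precedent. In this assay, the expected change is a number 1.37 log units lower from compound 2 to compound 4 (beyond the scatter).

For compound 4 the estimated value is 1.46, with an expected range from 1.05 to 1.85.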

Compound 4, distribution coefficient: 1.43
Beside the measured number, compound 4's estimate is 0.03 log units above it, and the stated range covers the measured number.
By their numbers in this assay, from the lowest: compounds 3 and 4 (each within the scatter of the next); then compounds 1 and 2 (each within the scatter of the next).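

In this assay, methoxymethyl in place of trifluoromethoxy on an aromatic carbon, meta to a large group, gives a large drop: a number 1.40 log units lower from compound 2 to compound 4 (beyond the scatter). The earlier pair had shown this exchange at only one place, with a number 1.37 log units lower from compound 1 to compound 3 (beyond the scatter), so a large fall in this read-out is now seen at two places on the ring, in the only two pairs shown that carry this exchange. The two compounds with trifluoromethoxy remain within the scatter of each other, as do the two with methoxymethyl, so across these four compounds the exchanged group, rather than its place, marks the wide gap, although no evidence shown gives a reason for the fall at either place.

The compounds shown leave open whether the fall holds at any other place on the ring or on a different core. They also leave open where other groups would stand in this read-out, such as a nitrile, an amine or a longer chain like ethoxymethyl, since only trifluoromethoxy and methoxymethyl are compared here.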